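Isobutyl in Place of Isopropyl on the Sulfonyl Sulfur

A few compounds are considered here, and "the series" means these few. Any claim that something is new, unique, unknown or untested is made for them only; others in the source may bear on it.

Compound 1, `O=C([C@@H]1CCCN(S(=O)(=O)c2ccc(S(=O)(=O)N3CC[C@@H](O)C3)cc2)C1)N1CCC(F)(F)CC1`: 330 nM in a functional assay on BXPC-3 cells (Homo sapiens) for inhibition, read by MTT assay, with a stated time of 7 days; on this read-out lower numbers stand for stronger inhibition and higher numbers for weaker inhibition
Compound 2, `O=C([C@@H]1CCCN(S(=O)(=O)c2ccc(S(=O)(=O)N3CC[C@H](O)C3)cc2)C1)N1CCC(F)(F)CC1`: 580 nM
Compound 3, `CC(C)S(=O)(=O)c1ccc(S(=O)(=O)N2CCC[C@@H](C(=O)N3CCC(F)(F)CC3)C2)cc1`: 50 nM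

Compound 3 gives the lowest of the three numbers: a 6.6-fold lower number from compound 1 to compound 3 (0.82 log units; beyond the scatter) and a 12-fold lower number from compound 2 to compound 3 (1.06 log units; beyond the scatter). Compounds 1 and 2, which differ only in configuration (the fact that compounds 1 and 2 differ only in the configuration as drawn), show a 1.8-fold higher number from compound 1 to compound 2 (0.24 log units; within the scatter).

Compound 4, `CC(C)CS(=O)(=O)c1ccc(S(=O)(=O)N2CCC[C@@H](C(=O)N3CCC(F)(F)CC3)C2)cc1`, differs from compound 3 by isobutyl in place of isopropyl on a sulfonyl sulfur. Among the compounds with values here, no measured step alters the isopropyl group itself; the two steps into compound 3 concern a different replacement at the same sulfonyl sulfur and cannot size this one. With no evidence that a longer alkyl chain here moves the number, a step within the scatter is expected, a 1.1-fold higher number from compound 3 to compound 4 (0.04 log units; within the scatter). Compound 4 is therefore estimated at 55 nM, between 20 nM and 150 nM.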

Compound 4, half-maximal inhibitory concentration: 311 nM
For compound 4 the middle estimate is 5.7-fold (0.75 log units) below the measured one; measured number outside the range, above it.
By their numbers in this assay, from the lowest: compound 3; then compounds 4, 1 and 2 (each within the scatter of the next).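

The group on the sulfonyl sulfur proves sensitive to a change within the alkyl series, not only to the replacement of 3-hydroxypyrrolidin-1-yl, with a 6.2-fold higher number from compound 3 to compound 4 (0.79 log units; beyond the scatter). Isobutyl also stands level with both 3-hydroxypyrrolidin-1-yl compounds, with a 1.9-fold lower number from compound 2 to compound 4 (0.27 log units; within the scatter) and a 1.1-fold lower number from compound 1 to compound 4 (0.03 log units; within the scatter), so among these groups the low number of compound 3 belongs to isopropyl alone. Nothing shown gives a cause for these steps. As far as these compounds go, whether ethyl, cyclopropyl or tert-butyl on the same sulfur would keep the number of compound 3 remains open.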